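From Bromo to Amino on a Saturated Side Chain

The source may report more compounds than this note shows. Statements on the series, on what has been measured and on what is new or still open speak of the compounds shown alone.

Compound 2 `BrCCCc1ccc(-c2ccc(-c3cccs3)s2)s1` carries a 3-bromopropyl chain on its core. For the measured compounds named here, in an ADME assay on MDCK cells (Canis lupus familiaris) for cytotoxicity, read by MTT assay, with a stated time of 2 days (a lower number here means that less compound is tolerated, a higher number that more compound is tolerated), compound 2 gives 35300 nM, the only number so far, since compound 1 `BrCCCc1ccc(-c2ccc(CCCBr)s2)s1` in this assay shows "not determined" (no result reported). Compound 3 `NCCCc1ccc(-c2ccc(-c3cccs3)s2)s1` differs from compound 2 by amino in place of bromo on a saturated chain carbon, three bonds along the chain from an aromatic carbon. Going by the values given here, no measured pair shows this change, so the step is expected to stay within the usual scatter, with no clear direction, and the expectation is a 1.1-fold higher number from compound 2 to compound 3 (0.05 log units; within the scatter). For compound 3 the estimate in this assay is 40000 nM, ranging from 15000 nM to 100000 nM.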

Compound 3, half-maximal cytotoxic concentration: 18900 nM
Compound 3: middle estimate off by 2.1-fold (0.33 log units), on the high side, and the stated range covers the measured number.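

In this assay, for the compounds shown here, amino in place of bromo on this saturated chain gives a 1.9-fold lower number from compound 2 to compound 3 (0.27 log units; within the scatter) and so offers the first measured comparison at this position. On this one pair, the 3-bromopropyl and 3-aminopropyl chains cannot be told apart, and a single pair sets no general rule for the change. Nothing available here bears on why the two compounds read this way. Still open, going by these compounds, is how a carboxylic acid or a hydroxyl would read at the end of this chain, and whether a longer chain carrying the amino group would match the 3-aminopropyl chain.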